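Thioether side chain variation on the shared core

A few compounds are considered here, and "the series" means these few. Any claim that something is new, unique, unknown or untested is made for them only; others in the source may bear on it.

The series keeps one core and varies the group on a saturated chain carbon bound to a sulfur. Compound 1 `Cc1cc(Nc2cc(-c3ccccc3)[nH]n2)n2nc(SCCCc3ccccc3)nc2n1` carries phenethyl there; in a functional assay on MCF7 cells (Homo sapiens) for inhibition, read by MTT assay, with a stated time of 72 h (a higher number here means a weaker inhibitor, a lower number a stronger inhibitor), compound 1 gives 3900 nM. Compound 2 `Cc1cc(Nc2cc(-c3ccccc3)[nH]n2)n2nc(SCc3csc4ccccc34)nc2n1` carries 1-benzothiophen-3-yl and in this assay compound 2 gives 3470 nM. Compound 3 `Cc1cc(Nc2cc(-c3ccccc3)[nH]n2)n2nc(SCc3nc4ccccc4[nH]3)nc2n1` carries 1H-benzimidazol-2-yl and in this assay compound 3 gives 2730 nM. Compound 3 has the smallest of the three numbers, yet the steps of a 1.4-fold lower number from compound 1 to compound 3 (0.15 log units; within the scatter) and a 1.3-fold lower number from compound 2 to compound 3 (0.10 log units; within the scatter) both lie within the scatter, as does a 1.1-fold lower number from compound 1 to compound 2 (0.05 log units; within the scatter), so no ordering among the three can be read from these data.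

Compound 4 `Cc1cc(Nc2cc(-c3ccccc3)[nH]n2)n2nc(SCc3ccc(C(F)(F)F)cc3)nc2n1` is not yet measured. Its difference from compound 3: 4-(trifluoromethyl)phenyl in place of 1H-benzimidazol-2-yl on a saturated chain carbon bound to a sulfur. The three measured steps all concern the same position and together span a narrow band, so the expectation for the step from compound 3 to compound 4 is none beyond the scatter, as a 1.2-fold higher number from compound 3 to compound 4 (0.07 log units; within the scatter). On that basis compound 4 is estimated to give 3200 nM in this assay, with a range from 1500 nM to 7000 nM.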

Compound 4, half-maximal inhibitory concentration: 4820 nM
For compound 4 the middle estimate is 1.5-fold (0.18 log units) below the measured one; the measured number falls inside the stated range.
By their numbers in this assay, from the lowest: compounds 3, 2, 1 and 4 (each within the scatter of the next).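

Working notes on the thioether position. In this assay, the largest structural change so far gives a 1.8-fold higher number from compound 3 to compound 4 (0.25 log units; within the scatter) when the fused 1H-benzimidazol-2-yl group, with its hydrogen-bond donor and acceptor, gives way to 4-(trifluoromethyl)phenyl, a single six-membered aromatic ring with neither. The other two new comparisons also stay inside the band, with a 1.4-fold higher number from compound 2 to compound 4 (0.14 log units; within the scatter) and a 1.2-fold higher number from compound 1 to compound 4 (0.09 log units; within the scatter) leaving 4-(trifluoromethyl)phenyl indistinguishable from both 1-benzothiophen-3-yl and phenethyl on the saturated chain carbon bound to a sulfur. Nothing available explains this lack of separation among the four compounds.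

On these data alone, it remains open whether any group at this position can move the number beyond the scatter, and an amine, a carboxylic acid or a longer chain on the saturated chain carbon bound to a sulfur would be informative tests. All four compounds also share the same core, so these results do not show whether the same insensitivity to the side chain would hold if another part of the molecule were changed.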